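Carboxymethyl in Place of (Methoxycarbonyl)carbonyl: An Expected Outcome

The source may report more compounds than this note shows. Statements on the series, on what has been measured and on what is new or still open speak of the compounds shown alone.

Of the compounds shown here, three have been tested in a functional assay on CCRF-CEM cells (Homo sapiens); on this read-out lower numbers stand for higher toxicity in this test and higher numbers for lower toxicity in this test. Compound 1 `CCOC(=O)NC(=O)NC1=CS(=O)(=O)O[C@@]12[C@@H](CO[Si](C)(C)C(C)(C)C)O[C@@H](n1cc(C)c(=O)n(C)c1=O)[C@@H]2O[Si](C)(C)C(C)(C)C` gives 3000 nM. Compound 2 `COC(=O)C(=O)CNC1=CS(=O)(=O)O[C@@]12[C@@H](CO[Si](C)(C)C(C)(C)C)O[C@@H](n1cc(C)c(=O)n(C)c1=O)[C@@H]2O[Si](C)(C)C(C)(C)C`, which shares the same core, gives 5570 nM. Compound 3 `Cc1cn([C@@H]2O[C@@H]3COC4(O)CS(=O)(=O)O[C@@]34[C@H]2O[Si](C)(C)C(C)(C)C)c(=O)[nH]c1=O`, built on a different core, gives 100000 nM.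

Among these three numbers compound 2 stands second highest. The step of a 1.9-fold higher number from compound 1 to compound 2 (0.27 log units; within the scatter) lies within the scatter, so the two values cannot be told apart, while the number for compound 3 is far higher and clearly separated from compound 2.

Compound 4 `Cc1cn([C@@H]2O[C@H](CO[Si](C)(C)C(C)(C)C)[C@@]3(OS(=O)(=O)C=C3NCCC(=O)O)[C@H]2O[Si](C)(C)C(C)(C)C)c(=O)n(C)c1=O` has not yet been measured. It differs from compound 2 in one place: carboxymethyl in place of (methoxycarbonyl)carbonyl on a saturated chain carbon bound to an amine nitrogen

Going by the values given here, only one measured step touches the same region, the group on the amine nitrogen, and that step, a 1.9-fold higher number from compound 1 to compound 2 (0.27 log units; within the scatter), stayed within the scatter. Among the compounds with values here, this suggests that this part of the molecule can be altered without a large shift, but no measured compound carries a carboxymethyl group, and compound 3 shows that larger structural changes can move the number a long way. The expectation for compound 4 is a modest rise, a 1.8-fold higher number from compound 2 to compound 4 (0.25 log units; within the scatter), that may still fall inside the scatter. Compound 4 is estimated at 10000 nM, with a range from 3000 nM to 40000 nM.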

Compound 4, half-maximal cytotoxic concentration: 19400 nM
The estimate for compound 4 lay 1.9-fold (0.29 log units) below the measured number, within the range that was stated.
By their numbers in this assay, from the lowest: compounds 1 and 2 (each within the scatter of the next); then compound 4; then compound 3.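

Among compounds that differ only in the group on the amine nitrogen, the step from (methoxycarbonyl)carbonyl to carboxymethyl, a 3.5-fold higher number from compound 2 to compound 4 (0.54 log units; beyond the scatter), shows that this position can move the number in this assay beyond the scatter, which the earlier step there did not show. Replacing (ethoxycarbonyl)carbamoyl with 2-carboxyethyl on the same nitrogen gives a 6.5-fold higher number from compound 1 to compound 4 (0.81 log units; beyond the scatter), so the carboxyl-bearing chain stands clear of both earlier groups, on the side of lower toxicity in this test. Nothing available explains why the number rises with this change.

The compounds shown leave open whether the rise belongs to the free carboxylic acid itself or to the shape of the chain that carries it: a 2-(methoxycarbonyl)ethyl group or a primary amide on the same chain would help to separate the two, and a longer chain such as 3-carboxypropyl would test the chain length. They also leave open whether an amine at the end of that chain would push the number the same way, or the opposite way, on the shared core.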